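The compounds below may be only part of what the source reports. "The series", "measured", "known", "first", "only" and "open" are said of these compounds alone.

Of the compounds shown here, three sharing one core have been measured in a functional assay on CHO cells for agonist activity at Alpha-2C adrenergic receptor (Homo sapiens); on this read-out higher numbers stand for an effect only at larger amounts of compound and lower numbers for an effect already at smaller amounts. Compound 1 `CC(C)Oc1ccccc1OC(C)C1=NCCN1` gives 100 nM, compound 2 `CC(Oc1ccccc1OC1CC1)C1=NCCN1` gives 47.9 nM, and compound 3 `C=COc1ccccc1OC(C)C1=NCCN1` gives 631 nM. Within this set compound 3 stands highest of the three numbers: the step of a 6.3-fold higher number from compound 1 to compound 3 (0.80 log units; beyond the scatter) is modest, and the step of a 13-fold higher number from compound 2 to compound 3 (1.12 log units; beyond the scatter) is large, while a 2.1-fold lower number from compound 1 to compound 2 (0.32 log units; beyond the scatter) is a modest step the other way.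

Compound 4 `CC(Oc1ccccc1S(C)(=O)=O)C1=NCCN1` has not yet been measured. It differs from compound 3 in one place: methylsulfonyl in place of vinyloxy on an aromatic carbon. None of the three measured steps bears directly on this change. All of them swap one group on the oxygen for another, whereas here the whole vinyloxy leaves and a methylsulfonyl enters, so the measured steps show only how strongly the read-out responds to what sits at this position. Because a 2.1-fold lower number from compound 1 to compound 2 (0.32 log units; beyond the scatter) and a 13-fold higher number from compound 2 to compound 3 (1.12 log units; beyond the scatter) both go well beyond the scatter, a step beyond the scatter in either direction is expected to be plausible for compound 4. For the measured compounds named here, with no measured precedent for the entering group, the estimate for compound 4 is 1500 nM, with a range from 300 nM to 8000 nM, which means an expected step of a 2.4-fold higher number from compound 3 to compound 4 (0.38 log units; beyond the scatter).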

Compound 4, half-maximal effective concentration: 316 nM
Beside the measured number, compound 4's estimate is 4.7-fold (0.68 log units) above it; low and high end bracket the measured number.
By their numbers in this assay, from the lowest: compound 2; then compound 1; then compounds 4 and 3 (each within the scatter of the next).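

In this assay, replacing vinyloxy with methylsulfonyl on this aromatic carbon gives a 2.0-fold lower number from compound 3 to compound 4 (0.30 log units; within the scatter), so the read-out does not separate these two groups, although the whole oxygen-linked group has been exchanged. The earlier compounds shown here varied only what sat on the oxygen, and this result shows that a group with no such oxygen link to the ring can take this place and keep a number in the range of compound 3. The other two ether groups still stand apart, with a 6.6-fold higher number from compound 2 to compound 4 (0.82 log units; beyond the scatter) for cyclopropyloxy and a 3.2-fold higher number from compound 1 to compound 4 (0.50 log units; beyond the scatter) for isopropoxy, so both give lower numbers than methylsulfonyl as well as vinyloxy.

Going by these compounds, it remains open whether an amine or a carboxylic acid on this aromatic carbon would fall with the cyclopropyloxy and isopropoxy compounds or with the vinyloxy and methylsulfonyl compounds. On these data alone, it is equally open how a longer chain in place of the methyl of the methylsulfonyl group, or a longer chain on the oxygen, would move the number. Nothing at hand gives a measured reason for how these groups rank in this assay.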